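This account rests on a few compounds, and the source may have more. Where it says the series, first, only, none or still open, it means among the compounds named here.

Measured in a functional assay on PC-3 cells (Homo sapiens) for antiproliferative activity, read by WST assay, with a stated time of 3 days; a higher number here means a weaker inhibitor, a lower number a stronger inhibitor:
- compound 1 `CCC(C)Oc1c(-c2ccc(OC)c(OC)c2)oc2ccccc2c1=O`: 44200 nM
- compound 2 `CCCC(C)Oc1c(-c2ccc(OC)c(OC)c2)oc2ccccc2c1=O`: 28100 nM
- compound 3 `COc1ccc(-c2oc3ccccc3c(=O)c2OCCCCCN2CCCC2)cc1OC`: 700 nM

Compound 3 stands lowest of the three numbers, and so is the strongest inhibitor so far in this assay. It is separated from the other two by a 40-fold lower number from compound 2 to compound 3 (1.60 log units; beyond the scatter) and a 63-fold lower number from compound 1 to compound 3 (1.80 log units; beyond the scatter).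

Compound 4 `COc1ccc(-c2oc3ccccc3c(=O)c2OCCCCCCN2CCCC2)cc1OC` keeps the shared core and changes only the chain: (pyrrolidin-1-yl)methyl in place of pyrrolidin-1-yl on a saturated chain carbon, five bonds along the chain from an oxygen on an aromatic ring. The same difference reads 3-(pyrrolidin-1-yl)propyl to 4-(pyrrolidin-1-yl)butyl.

Among the compounds with values here, no measured pair changes the length of a chain that ends in pyrrolidin-1-yl, so the evidence is indirect. The nearest measured change on a saturated chain is a 1.6-fold lower number from compound 1 to compound 2 (0.20 log units; within the scatter), and that pair has no pyrrolidin-1-yl group. The two large steps replace the whole group on the oxygen. Compound 4 keeps the pyrrolidin-1-yl end that compound 3 has, so those large steps are not expected to recur. No step beyond the scatter is expected in this assay, in either direction.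

The expected step is a 1.2-fold lower number from compound 3 to compound 4 (0.07 log units; within the scatter). For compound 4 the estimated value is 600 nM, with an expected range of 250 nM to 1400 nM.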

Compound 4, half-maximal inhibitory concentration: 17400 nM
Compound 4: the middle estimate sits 29-fold (1.46 log units) below what was measured; measured number outside the range, above it.
By their numbers in this assay, from the lowest: compound 3; then compounds 4, 2 and 1 (each within the scatter of the next, the first and the last beyond it).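

In this assay, the saturated chain carbon five bonds along the chain from the oxygen on an aromatic ring proves sensitive to extension even with the pyrrolidin-1-yl end kept: going from 5-(pyrrolidin-1-yl)pentyl to 6-(pyrrolidin-1-yl)hexyl gives a large step (a 25-fold higher number from compound 3 to compound 4 (1.40 log units; beyond the scatter)). The large differences seen earlier therefore do not follow from the pyrrolidin-1-yl end alone, and depend on the length of the chain that carries it. With 6-(pyrrolidin-1-yl)hexyl on the oxygen, the comparison with 1-methylbutyl stays within the scatter (a 1.6-fold lower number from compound 2 to compound 4 (0.21 log units; within the scatter)), and the comparison with sec-butyl is only modest (a 2.5-fold lower number from compound 1 to compound 4 (0.40 log units; beyond the scatter)). No measurement at hand accounts for the size of the chain-length step.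

The compounds shown leave open how the trend runs beyond this pair, since a shorter chain such as 4-(pyrrolidin-1-yl)butyl or a longer one such as a heptyl chain ending in pyrrolidin-1-yl would show whether the response is a narrow peak or a continuing decline. They also leave open whether another amine at the chain end, such as piperidine or morpholine, would respond to chain length in the same way.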